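Trading an acrylamide-type group for an ester on the urea

The source may report more compounds than this note shows. Statements on the series, on what has been measured and on what is new or still open speak of the compounds shown alone.

Three compounds share one core, differing only in the side chain carried on the bicyclic sulfonate ring. Compound 3 `C=C(C)C(=O)NC(=O)NC1=CS(=O)(=O)O[C@@]12[C@@H](CO[Si](C)(C)C(C)(C)C)O[C@@H](n1cc(C)c(=O)n(C)c1=O)[C@@H]2O[Si](C)(C)C(C)(C)C` carries a ((1-methylethenyl)carbonyl)carbamoyl group there; in a functional assay on HEL cells (Homo sapiens) for cytotoxicity, read by microscopy (a higher number here means that more compound is tolerated, a lower number that less compound is tolerated), compound 3 gives 20000 nM, the lowest of the two numbers that were obtained. Compound 1 `Cc1cn([C@@H]2O[C@H](CO[Si](C)(C)C(C)(C)C)[C@@]3(OS(=O)(=O)C=C3NCC(=O)C(=O)N3CCC3)[C@H]2O[Si](C)(C)C(C)(C)C)c(=O)n(C)c1=O` gives 65000 nM in this assay. Compound 2 `CC(=O)NC1=CS(=O)(=O)O[C@@]12[C@@H](CO[Si](C)(C)C(C)(C)C)O[C@@H](n1cc(C)c(=O)n(C)c1=O)[C@@H]2O[Si](C)(C)C(C)(C)C` reached only a limit of this assay, >= 80000 nM. The two steps that end at compound 3 both moved tolerance downward: a 3.3-fold lower number from compound 1 to compound 3 (0.51 log units; beyond the scatter) and an at least 4.0-fold lower number from compound 2 to compound 3 (0.60 log units; beyond the scatter).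

Compound 4 `CCOC(=O)CNC(=O)NC1=CS(=O)(=O)O[C@@]12[C@@H](CO[Si](C)(C)C(C)(C)C)O[C@@H](n1cc(C)c(=O)n(C)c1=O)[C@@H]2O[Si](C)(C)C(C)(C)C` differs from compound 3 in one place: (ethoxycarbonyl)methyl in place of (1-methylethenyl)carbonyl on an amide-type nitrogen. Among the measured compounds shown here, since both measured changes into the (1-methylethenyl)carbonyl region lowered the tolerated concentration, removing that group is expected to raise it again, back toward compound 1 and compound 2, though the ((ethoxycarbonyl)methyl)carbamoyl group is new and has no direct precedent here. The expected step is a 2.5-fold higher number from compound 3 to compound 4 (0.40 log units; beyond the scatter), a modest rise. Compound 4 is therefore estimated at 50000 nM, most likely between 20000 nM and 100000 nM.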

Compound 4, minimum cytotoxic concentration: 16000 nM
The estimate for compound 4 lay 3.1-fold (0.49 log units) above the measured number; measured number outside the range, below it.
By their numbers in this assay, from the lowest: compounds 4 and 3 (each within the scatter of the next); then compound 1. At a limit, above all of these: compound 2.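

In this assay, putting (ethoxycarbonyl)methyl in place of (1-methylethenyl)carbonyl on the amide-type nitrogen gives a 1.3-fold lower number from compound 3 to compound 4 (0.10 log units; within the scatter), so the two groups cannot be told apart at this position. Compound 4 also shows a 4.1-fold lower number from compound 1 to compound 4 (0.61 log units; beyond the scatter) and an at least 5.0-fold lower number from compound 2 to compound 4 (0.69 log units; beyond the scatter), so among these four compounds the lower numbers go with the carbamoyl link that compounds 3 and 4 share, whichever of the two groups sits at its end. The step from compound 2 is only a floor, as compound 2 stands at a limit: the limit of >= 80000 nM in this assay, at which 1 of the 4 values shown sits.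

Still open, going by these compounds, is how a carbamoyl group ending in a plain ethyl chain, or in a carboxylic acid instead of the ethyl ester, would read in this assay. On these data alone, a primary amine at the same place is equally open.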